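The compounds below may be only part of what the source reports. "The series", "measured", "known", "first", "only" and "open" are said of these compounds alone.

Compound 1 `CCOC(=O)N1CCC(Oc2cc(Oc3ccc(/C=C4\SC(=O)NC4=O)cc3)ncn2)CC1` carries an ethoxycarbonyl group on its piperidine, and compound 2 `CC(C)(C)OC(=O)N1CCC(Oc2cc(Oc3ccc(/C=C4\SC(=O)NC4=O)cc3)ncn2)CC1` the tert-butoxycarbonyl analogue. In a functional assay on CHO-K1 cells for agonist activity at Glucose-dependent insulinotropic receptor (Homo sapiens), read by cAMP accumulation and immunoassay, with a stated time of 1 h (on this read-out lower numbers stand for smaller maximal responses and higher numbers for larger maximal responses), compound 1 reaches 51.8%, while compound 2 reaches 122%. The change tert-butyl in place of ethyl on an oxygen next to a carbonyl group therefore produced a step of a number 70.2 percentage points higher from compound 1 to compound 2 (beyond the scatter).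

Compound 3 `CCOC(=O)N1CCC(Oc2cc(Oc3cccc(/C=C4\SC(=O)NC4=O)c3)ncn2)CC1` has the same atoms as compound 1 joined differently; the difference between the two cores is not broken down here. In this assay compound 3 gives 43.3%, a value within the scatter of compound 1.

Compound 4 `CC(C)(C)OC(=O)N1CCC(Oc2cc(Oc3cccc(/C=C4\SC(=O)NC4=O)c3)ncn2)CC1` stands to compound 3 as compound 2 stands to compound 1: the change tert-butyl in place of ethyl on an oxygen next to a carbonyl group is the same change, at the same place. Among the measured compounds shown here, because the one measured instance of this change gave a number 70.2 percentage points higher from compound 1 to compound 2 (beyond the scatter), a step of similar size is expected from compound 3, namely a number 61.7 percentage points higher from compound 3 to compound 4 (beyond the scatter), though this rests on a single pair and a maximal response cannot rise without bound. Compound 4 is therefore estimated to reach 105% in this assay, within a range from 70% to 135%.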

Compound 4, largest response reached (Emax), in percent of the reference or control that the assay uses: 78.3%
Beside the measured number, compound 4's estimate is 26.7 percentage points above it; low and high end bracket the measured number.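

On the core of compound 3, tert-butyl in place of ethyl on an oxygen next to a carbonyl group gave a number 35 percentage points higher from compound 3 to compound 4 (beyond the scatter) in this assay, so the direction of the change carried over from the core of compound 1, while its size did not: the same change on two cores in this assay, a number 70.2 percentage points higher (beyond the scatter) from compound 1 to compound 2 and a number 35 percentage points higher (beyond the scatter) from compound 3 to compound 4, 35.2 percentage points apart, beyond the scatter of two such steps

The change thus raised the maximal response on both cores, but the amount gained differed with the core, so a step read on one core gave its direction on the other and not a number that could be transferred. Two pairs cannot show why the steps differ, nor how the change would behave on any further core.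

The compounds shown leave open where isopropyl, a longer chain such as n-butyl, or cyclopropyl on that oxygen would fall relative to ethyl and tert-butyl. Also open, going by these compounds, is how an amide or a urea in place of the ethoxycarbonyl or tert-butoxycarbonyl group would behave in this assay.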